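The source may report more compounds than this note shows. Statements on the series, on what has been measured and on what is new or still open speak of the compounds shown alone.

Compound 3 `Cc1ccccc1S(=O)(=O)N1CCC[C@H]1C(=O)Nc1ccc(C(=O)O)cc1` gives 40.1% in a functional assay on the whole organism for inhibition, with Rattus norvegicus as the target, read by paw edema, with stated times of 1 h and 3 h, at a dose of 100 mg/kg by the oral route (a higher number here means more inhibition at the dose given (going by the name of the read-out), a lower number less inhibition), the highest of the three measured compounds. Compound 1 `Cc1ccccc1S(=O)(=O)N1CC(O)C[C@H]1C(=O)Nc1ccc(C(=O)O)cc1` gives 25.3%, and compound 2 `O=C(O)c1ccc(NC(=O)[C@@H]2CC(O)CN2S(=O)(=O)c2ccccc2)cc1` gives 1.85%. Compound 3 is reached from compound 1 by the step of a number 14.8 percentage points higher from compound 1 to compound 3 (beyond the scatter). Compound 4 `O=C(O)c1ccc(NC(=O)[C@@H]2CCCN2S(=O)(=O)c2ccccc2)cc1` differs from compound 3 by hydrogen in place of methyl on an aromatic carbon. Going by the values given here, the only measured step of this same kind, hydrogen in place of methyl on an aromatic carbon, is a number 23.5 percentage points lower from compound 1 to compound 2 (beyond the scatter), a drop beyond the scatter. A drop of roughly that size is therefore expected for compound 4, which means the estimated step of a number 23.1 percentage points lower from compound 3 to compound 4 (beyond the scatter). Compound 4 is thus expected to give about 17% in this assay, most plausibly somewhere between 0% and 35%.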

Compound 4, a percentage reported as inhibition, in the whole organism at one dose (the size of the read-out at that dose, not a potency): 31.2%
The estimate for compound 4 lay 14.2 percentage points below the measured number, and the stated range covers the measured number.
By their numbers in this assay, from the lowest: compound 2; then compounds 1, 4 and 3 (each within the scatter of the next, the first and the last beyond it).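

Replacing 2-methylphenyl with phenyl has no fixed effect in this assay, and on the core without the hydroxy the step reads a number 8.9 percentage points lower from compound 3 to compound 4 (within the scatter): the same change on two cores in this assay, a number 23.5 percentage points lower (beyond the scatter) from compound 1 to compound 2 and a number 8.9 percentage points lower (within the scatter) from compound 3 to compound 4, 14.6 percentage points apart, beyond the scatter of two such steps

Replacing the hydroxy on the saturated ring with hydrogen also varies with the core, reading a number 29.4 percentage points higher from compound 2 to compound 4 (beyond the scatter): the same change on two cores in this assay, a number 14.8 percentage points higher (beyond the scatter) from compound 1 to compound 3 and a number 29.4 percentage points higher (beyond the scatter) from compound 2 to compound 4, 14.6 percentage points apart, beyond the scatter of two such steps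

Of these two cores, the methyl makes a difference beyond the scatter only on the one that carries the hydroxy.

The compounds shown leave open whether an ethyl group or a chlorine atom at this place would behave like the methyl. They also cannot tell why the two changes depend on each other.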